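From 4-methylbenzyl to 2,4-difluorobenzyl

The compounds below may be only part of what the source reports. "The series", "measured", "known", "first", "only" and "open" are said of these compounds alone.

In a functional assay on MCF cells (Homo sapiens) for antiproliferative activity, with a stated time of 72 h (on this read-out lower numbers stand for stronger inhibition and higher numbers for weaker inhibition), compound 1 `OC[C@H]1O[C@@H](n2cnc3c(NCc4ccc(Cl)cc4)ncnc32)[C@H](O)[C@@H]1O` gives > 166000 nM as a limit of the assay and not a number. Compound 2 `Cc1ccc(CNc2ncnc3c2ncn3[C@@H]2O[C@H](CO)[C@@H](O)[C@H]2O)cc1` gives > 166000 nM as a limit too, which places it at the limit of > 166000 nM in this assay, at which 2 of the 3 values shown sit, and leaves its true value unknown. Compound 3 `OC[C@H]1O[C@@H](n2cnc3c(NCc4ccc(Cl)c(Cl)c4)ncnc32)[C@H](O)[C@@H]1O` gives an actual number, 88800 nM in this assay under the same conditions.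

Compound 4 `OC[C@H]1O[C@@H](n2cnc3c(NCc4ccc(F)cc4F)ncnc32)[C@H](O)[C@@H]1O` departs from compound 2 by one change: 2,4-difluorophenyl in place of 4-methylphenyl on a saturated chain carbon bound to a nitrogen on an aromatic ring with 2,4-difluorophenyl in place of 4-methylphenyl on a saturated chain carbon bound to a nitrogen on an aromatic ring. On these data alone, the measured steps nearest to it are an at least 1.8-fold lower number from compound 2 to compound 3 (0.27 log units; that floor lies within the scatter) and an at least 1.8-fold lower number from compound 1 to compound 3 (0.27 log units; that floor lies within the scatter) while a step that the two limits leave unreadable from compound 1 to compound 2 remains open. None of them carries a 2,4-difluorophenyl group, so no shift beyond the scatter is expected in this assay for this change. The estimated change is an at least 1.1-fold lower number from compound 2 to compound 4 (0.04 log units; that floor lies within the scatter) and no more than that. Compound 4 is expected at about 150000 nM with an estimated range from 80000 nM to 250000 nM and may well prove to be only a limit.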

Compound 4, half-maximal inhibitory concentration: > 166000 nM
Compound 4 gave a limit, no number (the forecaster's own chance of this, stated with the estimate: 65%); middle value at least 1.1-fold (0.04 log units) from the limit.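

In this assay compound 4 gives > 166000 nM, a limit of the assay and not a number, so 2,4-difluorophenyl on a saturated chain carbon bound to a nitrogen on an aromatic ring does not bring this read-out to a number. Among these compounds, compound 4 thereby joins compound 1 and compound 2, leaving compound 3, with its 3,4-dichlorophenyl group, as the only one of the four with a number: the limit of > 166000 nM in this assay, at which 3 of the 4 values shown sit. The steps to compound 4 from compound 1 and from compound 2 cannot be read, and the one readable step is an at least 1.8-fold higher number from compound 3 to compound 4 (0.27 log units; that floor lies within the scatter).

The compounds shown leave open how far apart the three compounds at the limit truly lie. They also leave open what a methoxy group on the phenyl ring, or a longer chain in place of the benzyl group, would give.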